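The source may report more compounds than this note shows. Statements on the series, on what has been measured and on what is new or still open speak of the compounds shown alone.

This account follows a small set of compounds that share one core and were tested in a functional assay on PC-3 cells (Homo sapiens) for inhibition, read by sulforhodamine B assay, with a stated time of 48 h; a higher number here means a weaker inhibitor of growth, a lower number a stronger inhibitor of growth. Compound 1 `Nc1cc(N)c2nc(-c3ccccc3)c(Oc3ccc(Cl)c(Cl)c3)nc2c1` gives 14500 nM. Among the two plain numbers in this assay, compound 1 holds the higher one; the nearest is compound 2 `Nc1cc(N)c2nc(-c3ccccc3)c(NCc3ccc(Cl)c(Cl)c3)nc2c1`, which gives 5130 nM, a gap beyond the usual scatter of the measurement. Compound 3 `CCOC(=O)[C@H](CCC(=O)O)NC(=O)c1ccc(Sc2nc3cc(N)cc(N)c3nc2-c2ccccc2)cc1` has only a limit in this assay, < 100000 nM, and not a number.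

The compound still to be measured is compound 4 `Nc1cc(N)c2nc(-c3ccccc3)c(Sc3ccc(F)cc3)nc2c1`. It differs from compound 1 in one place: (4-fluorophenyl)sulfanyl in place of 3,4-dichlorophenoxy on an aromatic carbon. The new group sits on the same aromatic carbon of the six-membered aromatic ring with 2 nitrogen, next to the ring nitrogen and ortho to the phenyl group.

Going by the values given here, no pair of measured compounds shows this change, so there is nothing to set its size against. The expectation is a step from compound 1 to compound 4 of a 1.0-fold higher number from compound 1 to compound 4 (0.01 log units; within the scatter), that is, no change beyond the scatter in either direction. Compound 4 is therefore estimated at 15000 nM, in a range from 5000 nM to 50000 nM.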

Compound 4, concentration for total growth inhibition: < 100000 nM
Compound 4: only a limit was reported (the forecaster's own chance of this, stated with the estimate: 10%); the middle value lies beyond the limit too.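

The step from compound 1 to compound 4 cannot be read, because compound 4 has only a limit and not a number in this assay: the limit of < 100000 nM in this assay, at which 2 of the 4 values shown sit. The compounds shown leave open how (4-fluorophenyl)sulfanyl compares with 3,4-dichlorophenoxy on the shared core.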